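Acyl swap on the shared core: outlook for compound 4

The source may report more compounds than this note shows. Statements on the series, on what has been measured and on what is new or still open speak of the compounds shown alone.

Measured so far in a functional assay on ACHN cells (Homo sapiens) for cytotoxicity, read by sulforhodamine B assay, with a stated time of 72 h; a higher number here means a weaker inhibitor of growth, a lower number a stronger inhibitor of growth:
compound 1, `O=C(Nc1cc(C(F)(F)F)cc(C(F)(F)F)c1)C1CCc2ccccc2N1C(=O)c1ccccc1Cl`, gives 4700 nM
compound 2, `CC(=O)N1c2ccccc2CCC1C(=O)Nc1cc(C(F)(F)F)cc(C(F)(F)F)c1`, gives > 70000 nM
compound 3, `CC(=O)N1c2ccccc2CCC1C(=O)Nc1ccccc1C(F)(F)F`, gives > 80000 nM

The value of compound 2 is a limit of this assay (the limit of > 70000 nM in this assay, at which 1 of the 3 values shown sits). The value of compound 3 is likewise a limit (the limit of > 80000 nM in this assay, at which 1 of the 3 values shown sits). Compound 1 and compound 2 differ by 2-chlorophenyl in place of methyl on a carbonyl carbon, and this step is an at least 14-fold lower number from compound 2 to compound 1 (1.17 log units; beyond the scatter). The difference between the core of compound 2 and the core of compound 3 is not broken down here.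

Compound 4, `O=C(Nc1ccccc1C(F)(F)F)C1CCc2ccccc2N1C(=O)c1ccccc1Cl`, is not yet measured in this assay; it differs from compound 3 by 2-chlorophenyl in place of methyl on a carbonyl carbon, the same change as from compound 2 to compound 1.

Resting on the step from compound 2 to compound 1 in this assay an at least 14-fold lower number from compound 2 to compound 1 (1.17 log units; beyond the scatter), a step of an at least 8.0-fold lower number from compound 3 to compound 4 (0.90 log units; beyond the scatter) is expected for compound 4. Compound 4 is estimated at 10000 nM, between 3000 nM and 50000 nM.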

Compound 4, concentration for 50% growth inhibition: 3900 nM
Compound 4: the middle estimate sits 2.6-fold (0.41 log units) above what was measured; low and high end bracket the measured number.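

In this assay, (2-chlorophenyl)carbonyl in place of acetyl gives an at least 20-fold lower number from compound 3 to compound 4 (1.31 log units; beyond the scatter), so the change carries to the second core as a large step in the same direction as on the first. Set side by side, the two steps read: the same change on two cores in this assay, an at least 14-fold lower number (1.17 log units; beyond the scatter) from compound 2 to compound 1 and an at least 20-fold lower number (1.31 log units; beyond the scatter) from compound 3 to compound 4; the limit leaves it open whether they differ. Compound 3 is held at a limit and not a number, so this step fixes no exact size, and two cores give no rule for other cores.

The compounds shown leave open whether the drop needs the chlorine, or whether a plain phenyl or a cyclohexyl on the same carbonyl would give it too. Also open, as far as these compounds go, is how an amine or a carboxylic acid on the entering ring would read.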